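A few compounds are considered here, and "the series" means these few. Any claim that something is new, unique, unknown or untested is made for them only; others in the source may bear on it.

The shared core of these compounds carries a single variable group on one aromatic carbon, and the question is how much of each compound the cells tolerate. In an ADME assay on BCBL1 cells (Homo sapiens) for cytotoxicity, with a stated time of 7 days (a lower number here means that less compound is tolerated, a higher number that more compound is tolerated), compound 1 `CCCCCCCCOc1nc(N)nc2c1ncn2/C=C1/CC1(CO)CO` gives > 20000 nM, which is a limit of the assay rather than a number. Compound 2 `Nc1nc(NCc2ccccc2)c2ncn(/C=C3/CC3(CO)CO)c2n1` gives 19900 nM in this assay. Compound 3 `CC(C)CNc1nc(N)nc2c1ncn2/C=C1/CC1(CO)CO` gives > 20000 nM, again a limit rather than a number. The step of a number no higher from compound 1 to compound 2 (the limit leaves the size open) and the step that the two limits leave unreadable from compound 1 to compound 3 therefore cannot be sized, and the same holds for a number no lower from compound 2 to compound 3 (the limit leaves the size open); the one firm point, through (the limit of > 20000 nM in this assay, at which 2 of the 3 values shown sit), is that compound 1 sits at the top of what the assay can report. Compound 4 `CCCCCCSc1nc(N)nc2c1ncn2/C=C1/CC1(CO)CO` differs from compound 1 by hexylsulfanyl in place of octyloxy on an aromatic carbon. The measured steps change the same position, but none of them is readable, so they give no direction for this change. Compound 4 is expected to stay close to compound 1, with an estimated step of a number no higher from compound 1 to compound 4 (the limit leaves the size open). The estimate for compound 4 is 20000 nM, between 10000 nM and 40000 nM, most likely reported again only as a limit.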

Compound 4, half-maximal cytotoxic concentration: > 20000 nM
Compound 4: no number, only a limit; the forecaster's own chance of this, stated with the estimate: 70%; the middle value lies on the limit itself.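

Compound 4 shows that this aromatic carbon can carry a sulfur-linked chain, hexylsulfanyl, in place of the oxygen-linked octyloxy and still give no measurable cytotoxicity within the range of this assay. None of the steps to compound 4 can be read, so the change has no size and says nothing about the effect of sulfur or of chain length. The result adds one more compound at the top of the reported range: the limit of > 20000 nM in this assay, at which 3 of the 4 values shown sit.

The compounds shown leave open whether any group on this carbon brings the tolerated amount clearly down, as compound 2 alone gives a number rather than a limit. As far as these compounds go, with a number no lower from compound 2 to compound 4 (the limit leaves the size open) as the only direction on offer, that question stays open. A carboxylic acid, a dimethylamino group or a chain longer than octyloxy at this place would be further tests of that question.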